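The source may report more compounds than this note shows. Statements on the series, on what has been measured and on what is new or still open speak of the compounds shown alone.

Measured compounds in a functional assay on HEK293 cells for antagonist activity at transient receptor potential cation channel subfamily V member 1 (Rattus norvegicus); a higher number here means a weaker inhibitor, a lower number a stronger inhibitor:
compound 1, `CC(C)c1ccc(NC(=O)N2CCN(c3ncccc3[N+](=O)[O-])CC2)cc1`, 245 nM
compound 2, `CC(C)c1ccc(NC(=O)N2CCN(c3ncccc3Cl)CC2)cc1`, 17.3 nM
compound 3, `CCc1cccnc1N1CCN(C(=O)Nc2ccc(C(C)C)cc2)CC1`, 828 nM

Compound 2 gives the lowest of the three numbers; the step of a 14-fold lower number from compound 1 to compound 2 (1.15 log units; beyond the scatter) is large, and a 48-fold higher number from compound 2 to compound 3 (1.68 log units; beyond the scatter) is large as well. All three measured steps concern the substituent on the pyridine ring of the shared core.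

Compound 4, `O=C(Nc1ccc(OC(F)(F)F)cc1)N1CCN(c2ncccc2Cl)CC1`, is not yet measured. It keeps the chloropyridine of compound 2 and differs only in trifluoromethoxy in place of isopropyl on an aromatic carbon. Among the compounds with values here, no measured step touches this position, so nothing among the three compounds bears directly on the change; the expectation rests on compound 2 alone. For compound 4 the estimate is 30 nM (range 6 nM to 150 nM), an expected step of a 1.7-fold higher number from compound 2 to compound 4 (0.24 log units; within the scatter), i.e. no change beyond the scatter is expected.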

Compound 4, half-maximal inhibitory concentration: 261 nM
Beside the measured number, compound 4's estimate is 8.7-fold (0.94 log units) below it; measured number outside the range, above it.
By their numbers in this assay, from the lowest: compound 2; then compounds 1 and 4 (each within the scatter of the next); then compound 3.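

In this assay, the substituent para to a large group on the ring of carbon only proves as sensitive as the pyridine substituent: trifluoromethoxy in place of isopropyl gives a 15-fold higher number from compound 2 to compound 4 (1.18 log units; beyond the scatter), a large step. With the chloropyridine held fixed, isopropyl therefore gives the lower number of this pair. No available evidence accounts for this step.

As far as these compounds go, whether the oxygen or the fluorines of trifluoromethoxy matter stays open; trifluoromethyl or tert-butyl at this position would help separate them. Also open, from the compounds shown here alone, is whether the step holds with nitro or ethyl on the pyridine.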